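The source may hold more compounds than are shown below. What is called first, only, known or untested is meant among the compounds shown, and "the series" means these compounds.

Measured so far in a functional assay on A549 cells (Homo sapiens) for antiproliferative activity, read by MTT assay, with a stated time of 72 h; on this read-out lower numbers stand for stronger inhibition and higher numbers for weaker inhibition:
- Compound 1 `COc1cc(-n2cnc3ccc(-c4ccc(C(C)=O)cc4)cc32)cc(OC)c1OC`: 2510 nM
- Compound 2 `COc1cc(-n2cnc3ccc(-c4cc(F)ccc4F)cc32)cc(OC)c1OC`: 7940 nM

Not yet measured: compound 3 `COc1cc(-n2cnc3ccc(-c4ccccc4)cc32)cc(OC)c1OC`.

Compound 2 has the higher of the two numbers, which makes it the weaker inhibitor of the pair. The next change removes both fluorines from its outer ring: phenyl in place of 2,5-difluorophenyl on an aromatic carbon. In words, this puts phenyl in place of 2,5-difluorophenyl on an aromatic carbon.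

Among the compounds with values here, only one measured step bears on this. It is a 3.2-fold higher number from compound 1 to compound 2 (0.50 log units; beyond the scatter), a modest step that came from putting 2,5-difluorophenyl in place of 4-acetylphenyl on an aromatic carbon. Within the data shown here, that step shows that swapping the group here can move the number, but no measured pair shows the loss of fluorine alone. A smaller step is therefore expected, and it may stay within the scatter. Among the measured compounds shown here, the expected direction is only a slight lean towards a lower number, since compound 2 at 7940 nM sits above the only other value, that of compound 1 at 2510 nM.

The estimated change is a 1.6-fold lower number from compound 2 to compound 3 (0.20 log units; within the scatter). For compound 3 the expected value in this assay is 5000 nM, with an estimated range from 1800 nM to 14000 nM.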

Compound 3, half-maximal inhibitory concentration: 3060 nM
For compound 3 the middle estimate is 1.6-fold (0.21 log units) above the measured one; the measured number falls inside the stated range.
By their numbers in this assay, from the lowest: compounds 1 and 3 (each within the scatter of the next); then compound 2.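

In this assay, the change from 2,5-difluorophenyl to phenyl gives a 2.6-fold lower number from compound 2 to compound 3 (0.41 log units; beyond the scatter), and this is the first pair shown that differs only in the two fluorines, so their presence on this ring goes with a change beyond the scatter. Putting hydrogen in place of acetyl gives a 1.2-fold higher number from compound 1 to compound 3 (0.09 log units; within the scatter), so this assay does not separate phenyl from 4-acetylphenyl at this position, and of the three groups only 2,5-difluorophenyl stands apart from the other two. Nothing available here accounts for the fluorines going with the higher number.

Because the compounds shown carry either both fluorines or none, it remains open whether a single fluorine would behave like the pair, and whether its place on the ring would matter. Within the data shown here, also open is how an amine, a carboxylic acid or a longer chain on this outer ring would compare with the plain phenyl of compound 3, since the acetyl is the only group of this kind among the three.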